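Replacing a Methylcyclopentyl Ether with an Acyclic Ether Chain

The compounds below may be only part of what the source reports. "The series", "measured", "known", "first", "only" and "open" are said of these compounds alone.

Compound 3 `CC1CCC(Oc2cccc3ccc(N)nc23)C1` is the weaker of the two compounds with a definite number in an assay on cells with melanin-concentrating hormone receptor 1 (Homo sapiens) as the target, read by radioligand binding (a higher number here means a weaker inhibitor, a lower number a stronger inhibitor), giving 823 nM; its nearest neighbour, compound 2 `Nc1ccc2cccc(OCC3CCCC3)c2n1`, gives 53 nM. Compound 1 `Nc1ccc2cccc(OC3CCC3)c2n1` reaches only the assay limit of > 2000 nM (the limit of > 2000 nM in this assay, at which 1 of the 3 values shown sits). Compound 4 `CCOCC(C)Oc1cccc2ccc(N)nc12` is still to be measured; the change is a group of 6 heavy atoms (5 carbon, 1 oxygen; no ring) in place of a group of 6 heavy atoms (6 carbon; one five-membered non-aromatic ring of carbon only), on an oxygen on an aromatic ring. For the measured compounds named here, two measured steps bear on it: an at least 2.4-fold lower number from compound 1 to compound 3 (0.38 log units; beyond the scatter) and a 16-fold higher number from compound 2 to compound 3 (1.19 log units; beyond the scatter), both showing that the group on this oxygen moves the number widely. Neither involves an acyclic ether, so the direction is open, and a step beyond the scatter either way is possible. Compound 4 is therefore expected near 800 nM (range 200 nM to 3000 nM), the estimated step being a 1.0-fold lower number from compound 3 to compound 4 (0.01 log units; within the scatter).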

Compound 4, half-maximal inhibitory concentration: 1070 nM
Compound 4: middle estimate off by 1.3-fold (0.13 log units), on the low side; low and high end bracket the measured number.
By their numbers in this assay, from the lowest: compound 2; then compounds 3 and 4 (each within the scatter of the next). At a limit, above all of these: compound 1.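

In this assay, an acyclic ether group carrying a hydrogen-bond acceptor in place of 3-methylcyclopentyl on this oxygen gives a 1.3-fold higher number from compound 3 to compound 4 (0.11 log units; within the scatter), so the two groups cannot be told apart here. It does not approach cyclopentylmethyl, with a 20-fold higher number from compound 2 to compound 4 (1.31 log units; beyond the scatter). Compound 1 stands at a limit of the assay: the limit of > 2000 nM in this assay, at which 1 of the 4 values shown sits. Against that limit the data give only an at least 1.8-fold lower number from compound 1 to compound 4 (0.27 log units; that floor lies within the scatter), so no firm size can be put on this step.

The compounds shown leave open whether an amine or a longer ether chain on this oxygen would come closer to compound 2. They also leave open whether a cyclopentylethyl group would.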